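A few compounds are considered here, and "the series" means these few. Any claim that something is new, unique, unknown or untested is made for them only; others in the source may bear on it.

Measured in a functional assay on U-87MG ATCC cells (Homo sapiens) for inhibition, read by MTT assay, with a stated time of 72 h; on this read-out lower numbers stand for stronger inhibition and higher numbers for weaker inhibition:
compound 1, `COc1cc2c(Oc3ccc(NC(=O)c4nn(-c5ccccc5C)c(=O)cc4C)cc3F)ccnc2cc1OCCCN1CCCC1`, gives 2960 nM
compound 2, `COc1cc2c(Oc3ccc(NC(=O)c4nn(-c5ccccc5C)c(=O)cc4C)cc3F)ccnc2cc1OCCCN1CCC(C)CC1`, gives 2240 nM
compound 3, `COc1cc2c(Oc3ccc(NC(=O)c4nn(-c5ccccc5C)c(=O)cc4C)cc3F)ccnc2cc1OCCCN1CCN(C)CC1`, gives 3720 nM

Compound 1 lies within the usual scatter of both of the others: a 1.3-fold lower number from compound 1 to compound 2 (0.12 log units; within the scatter), and a 1.3-fold higher number from compound 1 to compound 3 (0.10 log units; within the scatter); the remaining pair behaves the same way, a 1.7-fold higher number from compound 2 to compound 3 (0.22 log units; within the scatter). Each of these three steps alters only the amine at the end of the chain, leaving the rest of the shared core untouched.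

Compound 4, `COc1cc2c(Oc3ccc(NC(=O)c4nn(-c5ccc(Cl)cc5)c(=O)cc4C)cc3F)ccnc2cc1OCCCN1CCCC1`, differs from compound 1 at a different place: 4-chlorophenyl in place of 2-methylphenyl on an aromatic nitrogen. Going by the values given here, no measured step touches this aryl group, so the measured numbers give no guide to the size or direction of its effect; they show only a narrow band of values for the core.

Compound 4 is therefore estimated at 3000 nM, with a range from 900 nM to 10000 nM. For compound 4 this amounts to an expected step of a 1.0-fold higher number from compound 1 to compound 4 (0.01 log units; within the scatter) in this assay, with wide uncertainty.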

Compound 4, half-maximal inhibitory concentration: 1430 nM
Compound 4: middle estimate off by 2.1-fold (0.32 log units), on the high side; the range from low to high includes it.
By their numbers in this assay, from the lowest: compounds 4, 2, 1 and 3 (each within the scatter of the next, the first and the last beyond it).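

Unlike the amine swaps at the end of the chain, which all stayed within the scatter, the change on the aromatic nitrogen does move the number in this assay: 4-chlorophenyl in place of 2-methylphenyl gives a 2.1-fold lower number from compound 1 to compound 4 (0.32 log units; beyond the scatter). This position can therefore affect the read-out, though the step is modest. No available evidence explains the shift.

As far as these compounds go, the change removes the methyl and adds the chlorine at once, so the contribution of each remains open. Phenyl, 2-chlorophenyl and 4-methylphenyl at this position would help separate them.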